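Shortening the amino-acid arm in the naphthalene series

The source may hold more compounds than are shown below. What is called first, only, known or untested is meant among the compounds shown, and "the series" means these compounds.

Compound 1 `Nc1ncnc2c1ncn2[C@@H]1O[C@H](CN(CCCc2cccc3ccccc23)CCC[C@H](N)C(=O)O)[C@@H](O)[C@H]1O` gives 1100 nM in an assay on cells for inhibition of Nicotinamide N-methyltransferase (Homo sapiens), read by fluorescence and coupled enzyme assay, with a stated time of 10 min, in the presence of a further agent that is not named here; on this read-out higher numbers stand for weaker inhibition and lower numbers for stronger inhibition. Among the compounds with values here, compound 2 `Nc1ncnc2c1ncn2[C@@H]1O[C@H](CN(CCCc2ccc3ccccc3c2)CCC[C@H](N)C(=O)O)[C@@H](O)[C@H]1O` gives 33300 nM in this assay, the highest of the two numbers recorded so far; the single step leading to it, a 30-fold higher number from compound 1 to compound 2 (1.48 log units; beyond the scatter), is large and well beyond the scatter. Compound 3 `Nc1ncnc2c1ncn2[C@@H]1O[C@H](CN(CCCc2ccc3ccccc3c2)CC[C@H](N)C(=O)O)[C@@H](O)[C@H]1O` differs from compound 2 by amino(carboxy)methyl in place of 2-amino-2-carboxyethyl on a saturated chain carbon, two bonds along the chain from an amine nitrogen. Within the data shown here, no measured step bears on this change: the one step available, a 30-fold higher number from compound 1 to compound 2 (1.48 log units; beyond the scatter), moves the attachment point of the naphthalene and leaves the amino-acid arm untouched, so it gives no direction for the shortening. The expectation for compound 3 therefore rests on compound 2 alone and is set close to it, as an expected step of a 1.5-fold higher number from compound 2 to compound 3 (0.18 log units; within the scatter) with a wide range on both sides. Compound 3 is estimated at 50000 nM in this assay, expected between 12000 nM and 200000 nM.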

Compound 3, inhibition constant: 4000 nM
The estimate for compound 3 lay 13-fold (1.10 log units) above the measured number, outside the stated range (below it).
By their numbers in this assay, from the lowest: compound 1; then compound 3; then compound 2.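

Until now only the naphthalene attachment had been varied; the amino-acid arm turns out to matter as well. In this assay, the change from 3-amino-3-carboxypropyl to 2-amino-2-carboxyethyl in the naming cut one bond further out, with the naphthalen-2-yl group held fixed, gives an 8.3-fold lower number from compound 2 to compound 3 (0.92 log units; beyond the scatter), so this position on the saturated chain responds to arm length by a step beyond the scatter. Nothing measured on these compounds accounts for the step.

With naphthalen-1-yl, the effect of the same shortening cannot be read, as only the naphthalen-2-yl pair carries this step. Also open, from the compounds shown here alone, is how this position responds when the arm's amine or carboxylic acid is replaced, for instance by an amide in place of the carboxylic acid.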